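Replacing the Aryl on the Sulfonyl Sulfur

A few compounds are considered here, and "the series" means these few. Any claim that something is new, unique, unknown or untested is made for them only; others in the source may bear on it.

Measured compounds:
compound 1: `Cc1ccccc1S(=O)(=O)NC(=O)c1ccc(Nc2nc(NC3(c4ccc(Cl)cc4)CC3)nc(OCC(F)(F)F)n2)cc1`, 100%
compound 2: `CC(C)(C)NC(=O)NCCS(=O)(=O)NC(=O)c1ccc(Nc2nc(NC3(c4ccc(Cl)cc4)CC3)nc(OCC(F)(F)F)n2)cc1`, 96%
compound 3: `NCCS(=O)(=O)NC(=O)c1ccc(Nc2nc(NC3(c4ccc(Cl)cc4)CC3)nc(OCC(F)(F)F)n2)cc1`, 100%

Three compounds share one core and differ only in the group on the sulfonyl sulfur. In an ADME assay on microsomes from liver (Homo sapiens) for metabolic stability, with a stated time of 10 min (a higher number here means that more of the compound is left, a lower number that less of the compound is left), compound 1 gives 100%, level with compound 3 and together with it the highest of the three numbers; the remaining step, a number 4 percentage points lower from compound 1 to compound 2 (within the scatter), is within the scatter, as is a number 4 percentage points higher from compound 2 to compound 3 (within the scatter).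

Compound 4, `O=C(NS(=O)(=O)CCNCc1ccccc1)c1ccc(Nc2nc(NC3(c4ccc(Cl)cc4)CC3)nc(OCC(F)(F)F)n2)cc1`, is the next compound of the series and has not yet been measured. It differs from compound 1 in one place: 2-(benzylamino)ethyl in place of 2-methylphenyl on a sulfonyl sulfur.

Going by the values given here, two measured steps bear on this change, since both also replace the 2-methylphenyl on the sulfonyl sulfur with a substituted ethyl chain: a number 4 percentage points lower from compound 1 to compound 2 (within the scatter) and no change at the digits printed from compound 1 to compound 3 (within the scatter). Neither moved the number beyond the scatter, whether the chain carried a free amine or a (tert-butyl)carbamoyl group. A step of no more than the scatter is therefore expected in this assay for compound 4, with a number 5 percentage points lower from compound 1 to compound 4 (within the scatter). Compound 4 is estimated at 95%, in the range 80% to 100%.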

Compound 4, percent of the compound remaining: 99%
For compound 4 the middle estimate is 4 percentage points below the measured one, within the range that was stated.
By their numbers in this assay, from the lowest: compounds 2, 4, 1 and 3 (each within the scatter of the next).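

In this assay the 2-(benzylamino)ethyl group on the sulfonyl sulfur stays within the scatter of the 2-methylphenyl group, with a number 1 percentage points lower from compound 1 to compound 4 (within the scatter) as the step. The earlier compounds had shown the amine nitrogen of the chain only free or carrying (tert-butyl)carbamoyl, and benzyl on that nitrogen now gives a number 1 percentage points lower from compound 3 to compound 4 (within the scatter) and a number 3 percentage points higher from compound 2 to compound 4 (within the scatter) as its two steps, so across these compounds all three states of this nitrogen lie within the scatter of one another. Nothing available gives a reason for this result.

From the compounds shown here alone, whether a carboxylic acid at the end of the ethyl chain, a tertiary amine in place of the benzylamine, or a longer chain on the sulfonyl sulfur would also stay within the scatter remains open. So does the effect of substituents on the benzyl ring.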